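The source may hold more compounds than are shown below. What is called first, only, known or untested is meant among the compounds shown, and "the series" means these compounds.

Measured so far:

compound 1, `COc1cc(-c2nnc3n2NC(c2cccs2)C(C(=O)c2ccccc2)S3)cc(OC)c1OC`: 86300 nM
compound 2, `COc1cc(-c2nnc3n2NC(c2ccco2)C(C(=O)c2ccccc2)S3)cc(OC)c1OC`: 64300 nM

Both numbers come from a functional assay on PC-3 cells (Homo sapiens) for cytotoxicity, read by MTT assay, with a stated time of 48 h (a lower number here means a stronger inhibitor, a higher number a weaker inhibitor), and compound 2 holds the lower of the two. Among the compounds with values here, its only neighbour is compound 1, and the step of a 1.3-fold lower number from compound 1 to compound 2 (0.13 log units; within the scatter) lies within the scatter, so the two compounds cannot be told apart on these numbers; compound 2 is simply the one from which the next step is taken.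

Compound 3, `COc1cc(-c2nnc3n2NC(c2ccco2)C(C(=O)c2ccc([N+](=O)[O-])cc2)S3)cc(OC)c1OC`, differs from compound 2 by nitro in place of hydrogen on an aromatic carbon. Within the data shown here, no measured step touches this part of the molecule. Among the measured compounds shown here, the single measured step, a 1.3-fold lower number from compound 1 to compound 2 (0.13 log units; within the scatter), exchanges the ring on the saturated ring carbon, a different place, and was itself within the scatter; it therefore says nothing about what adding the nitro group might do. For the measured compounds named here, with no bearing step available, the expectation for compound 3 is a step of a 1.1-fold lower number from compound 2 to compound 3 (0.03 log units; within the scatter), that is, no change beyond the scatter, and the range around it is kept wide. In this assay compound 3 is expected to give 60000 nM, between 20000 nM and 180000 nM.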

Compound 3, half-maximal inhibitory concentration: 27900 nM
Compound 3: the middle estimate sits 2.2-fold (0.33 log units) above what was measured, and the stated range covers the measured number.
By their numbers in this assay, from the lowest: compound 3; then compounds 2 and 1 (each within the scatter of the next).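

In this assay, within the data shown here, nitro on an aromatic carbon of the six-membered aromatic ring of carbon only, para to a large group, gives a 2.3-fold lower number from compound 2 to compound 3 (0.36 log units; beyond the scatter) and so the first step here to pass beyond the scatter, though only modestly. The earlier exchange on the saturated ring carbon, a 1.3-fold lower number from compound 1 to compound 2 (0.13 log units; within the scatter), could not separate its two compounds, whereas this change from benzoyl to (4-nitrophenyl)carbonyl shows that the number can respond to a change on the phenyl ring. Nothing measured here bears on why the number fell with this change.

The compounds shown rest on this single group at this single place, so it remains open whether an amine, a methoxy group or a chlorine atom there would move the number in the same direction, and whether nitro elsewhere on that ring would do so. Going by these compounds, it is also open whether the same change would give a similar step on compound 1, which carries thiophen-2-yl in place of furan-2-yl.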